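A few compounds are considered here, and "the series" means these few. Any claim that something is new, unique, unknown or untested is made for them only; others in the source may bear on it.

Measured in a functional assay on MDA-MB-231 cells (Homo sapiens) for antiproliferative activity, read by MTT assay, with a stated time of 24 h; a higher number here means a weaker inhibitor, a lower number a stronger inhibitor:
- Compound 1 `O=C([C@H]1Cc2ccccc2N1)N1CCN(c2nccc(Oc3cc(Cl)cc(Cl)c3)n2)CC1`: > 50000 nM, a limit of the assay and not a number
- Compound 2 `Cc1ccc(NC(=O)N2CCN(c3nccc(Oc4cc(Cl)cc(Cl)c4)n3)CC2)cc1`: 11600 nM
- Compound 3 `O=C(Nc1cccc(Cl)c1)N1CCN(c2nccc(Oc3cc(Cl)cc(Cl)c3)n2)CC1`: 7900 nM

Among the measured compounds shown here, compound 3, at 7900 nM, holds one of only two true numbers in this small set. The other belongs to compound 2, and the two values lie within the scatter of each other.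

Compound 4 `O=C(Nc1ccc(C(F)(F)F)cc1)N1CCN(c2nccc(Oc3cc(Cl)cc(Cl)c3)n2)CC1` differs from compound 3 in one place, the group on the amide-type nitrogen: 4-(trifluoromethyl)phenyl in place of 3-chlorophenyl on an amide-type nitrogen. In words, 4-(trifluoromethyl)phenyl takes the place of 3-chlorophenyl.

For the measured compounds named here, the closest precedent is the only measured exchange of one substituted phenyl for another on this nitrogen, a 1.5-fold lower number from compound 2 to compound 3 (0.17 log units; within the scatter). The other two measured steps, an at least 4.3-fold lower number from compound 1 to compound 2 (0.63 log units; beyond the scatter) and an at least 6.3-fold lower number from compound 1 to compound 3 (0.80 log units; beyond the scatter), are larger, but they replace 2,3-dihydro-1H-indol-2-yl on the carbonyl carbon with a phenylamino group. That is a different change, and it says little about this one.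

Going by the values given here, no measured compound carries 4-(trifluoromethyl)phenyl, so the forecast remains uncertain. In this assay, no step beyond the scatter is expected, and the estimated step is a 1.2-fold lower number from compound 3 to compound 4 (0.08 log units; within the scatter). The expected value for compound 4 is 6500 nM, with an estimated range from 2500 nM to 16000 nM.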

Compound 4, half-maximal inhibitory concentration: 1540 nM
Compound 4: the middle estimate sits 4.2-fold (0.63 log units) above what was measured, outside the stated range (below it).
By their numbers in this assay, from the lowest: compound 4; then compounds 3 and 2 (each within the scatter of the next). At a limit, above all of these: compound 1.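

In this assay, among the compounds shown here, the group on this amide-type nitrogen can matter after all: the only earlier exchange of one substituted phenyl for another stayed within the scatter, but 4-(trifluoromethyl)phenyl in place of 3-chlorophenyl gives a 5.1-fold lower number from compound 3 to compound 4 (0.71 log units; beyond the scatter), and trifluoromethyl in place of methyl on an aromatic carbon gives a 7.5-fold lower number from compound 2 to compound 4 (0.88 log units; beyond the scatter). Compared with the carbonyl-linked 2,3-dihydro-1H-indol-2-yl group, the (4-(trifluoromethyl)phenyl)amino group gives an at least 32-fold lower number from compound 1 to compound 4 (1.51 log units; beyond the scatter), so the true size of this step is known only as a lower bound. Compound 1 stands at a limit of the assay and not at a number: the limit of > 50000 nM in this assay, at which 1 of the 4 values shown sits.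

The compounds shown do not settle whether the gain belongs to the trifluoromethyl group itself or to its place on the ring, a question that 3-(trifluoromethyl)phenyl and 4-chlorophenyl would address. As far as these compounds go, it also remains open how a nitrile or a methoxy group in place of the trifluoromethyl would read, or a cyclohexyl ring in place of the phenyl ring.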